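Replacing the Propyl Chain of Compound 2 with Fluorobenzyl

This account rests on a few compounds, and the source may have more. Where it says the series, first, only, none or still open, it means among the compounds named here.

Compound 1 `CSc1nnc(COc2cc(C)c3c(C)cc(=O)oc3c2)o1` — > 100000 nM
Compound 2 `CCCS(=O)(=O)c1nnc(COc2cc(C)c3c(C)cc(=O)oc3c2)o1` — 7070 nM
Compound 3 `Cc1cc(OCc2nnc(S(=O)(=O)Cc3cccc(F)c3)o2)cc2oc(=O)cc(C)c12` — not yet measured

In a functional assay on MDA-MB-231 cells (Homo sapiens) for antiproliferative activity, read by MTT assay, with a stated time of 24 h (a lower number here means a stronger inhibitor, a higher number a weaker inhibitor), compound 1 gives > 100000 nM, which is a limit of the assay rather than a number. Among the measured compounds shown here, compound 2 gives 7070 nM and is thus the only compound of the pair with a measured number; the other reading sits at the limit of > 100000 nM in this assay, at which 1 of the 2 values shown sits. For the measured compounds named here, the one measured step, an at least 14-fold lower number from compound 1 to compound 2 (1.15 log units; beyond the scatter), concerns the exchange of a methylsulfanyl group for a propylsulfonyl group and is large.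

Compound 3 differs from compound 2 by 3-fluorophenyl in place of ethyl on a saturated chain carbon bound to a sulfonyl sulfur. The measured step does not touch this change: it alters the sulfur substituent itself, whereas the step to compound 3 keeps the sulfonyl and only swaps the chain beyond it. Going by the values given here, no measured compound therefore tells how this swap should read. The estimate for compound 3 is a step within the scatter, a 1.4-fold lower number from compound 2 to compound 3 (0.15 log units; within the scatter), in the sense that no change beyond it is expected. Compound 3 is thus expected to give about 5000 nM, within the range 1500 nM to 20000 nM.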

Compound 3, half-maximal inhibitory concentration: 21300 nM
For compound 3 the middle estimate is 4.3-fold (0.63 log units) below the measured one; the whole stated range lies below it.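

The chain beyond the sulfonyl turns out not to be a silent place on this scaffold: in this assay, exchanging propyl for 3-fluorobenzyl gives a 3.0-fold higher number from compound 2 to compound 3 (0.48 log units; beyond the scatter), a modest step that runs against the large one seen earlier at the sulfur substituent itself, an at least 14-fold lower number from compound 1 to compound 2 (1.15 log units; beyond the scatter). Compound 3 still gives a measured number, 21300 nM, so with the sulfonyl kept the larger aromatic group moves the reading without taking it out of the measurable range, yet in this one pair the 3-fluorophenyl brings no gain over ethyl on a saturated chain carbon bound to a sulfonyl sulfur. Nothing measured here gives a reason for this shift.

The compounds shown leave open how much of the step belongs to the aromatic ring and how much to the fluorine, a question on which a plain benzyl group on the sulfonyl would bear. They also leave open how a longer chain such as butyl, or a chain ending in an amine, would read at the same place.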